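From phenyl to 4-methylbenzyl on the amide nitrogen

The compounds below may be only part of what the source reports. "The series", "measured", "known", "first", "only" and "open" are said of these compounds alone.

Measured in an ADME assay on MT4 cells (Homo sapiens) for cytotoxicity, read by MTT assay; on this read-out lower numbers stand for higher toxicity in this test and higher numbers for lower toxicity in this test:
Compound 1 `O=C(Nc1ccccc1)C1C(=O)N(O)C(=O)c2ccccc21`: 106000 nM
Compound 2 `COc1ccc(NC(=O)C2C(=O)N(O)C(=O)c3ccccc32)cc1Cl`: 12300 nM

Compound 1 stands higher of the two in this assay, and the gap down to compound 2 lies beyond the usual scatter. Compound 3 `Cc1ccc(CNC(=O)C2C(=O)N(O)C(=O)c3ccccc32)cc1` carries 4-methylbenzyl in place of phenyl on an amide-type nitrogen. For the measured compounds named here, no measured pair shows this change. With only compound 1 and compound 2 at 12300 nM as a guide, a small step towards a lower number is expected, perhaps none beyond the scatter. The expected change is a 1.9-fold lower number from compound 1 to compound 3 (0.28 log units; within the scatter). For compound 3 the estimate is 55000 nM, with an expected range of 18000 nM to 150000 nM.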

Compound 3, half-maximal cytotoxic concentration: > 125000 nM
Compound 3: no number, only a limit (the forecaster's own chance of this, stated with the estimate: 15%); at least 2.2-fold (0.35 log units) between middle value and limit.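

In this assay, compound 3 gives only a limit, > 125000 nM. Putting 4-methylbenzyl in place of phenyl on the amide-type nitrogen gives an at least 1.1-fold higher number from compound 1 to compound 3 (0.07 log units; that floor lies within the scatter), so this position accepts the larger group without the number falling. The size of the step stays unknown because the read-out ends in a limit: the limit of > 125000 nM in this assay, at which 1 of the 3 values shown sits.

The compounds shown leave open how much of this result belongs to the methyl and how much to the benzyl link, which plain benzyl would separate. They also leave open whether an amine or a carboxylic acid at this nitrogen's substituent would keep the number this high.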